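Swapping methoxy for oxolanyloxy on a shared core

The source may report more compounds than this note shows. Statements on the series, on what has been measured and on what is new or still open speak of the compounds shown alone.

Of the compounds shown here, two built on the same core have been measured in a functional assay on PC-3 cells (Homo sapiens) for antiproliferative activity, read by MTT assay, with a stated time of 72 h; a higher number here means a weaker inhibitor, a lower number a stronger inhibitor. Compound 2, with the structure `COc1cc2ncnc(N3CCCc4ccccc43)c2cc1NC(=O)/C=C/CN1CCC(CO)CC1`, gives 7150 nM. Compound 1, with the structure `C/C=C/C(=O)Nc1cc2c(N3CCCc4ccccc43)ncnc2cc1O[C@@H]1CCOC1`, gives 9350 nM in this assay, and the two numbers lie within the usual scatter of each other, so neither can be set apart from the other.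

Compound 3, with the structure `O=C(/C=C/CN1CCC(CO)CC1)Nc1cc2c(N3CCCc4ccccc43)ncnc2cc1O[C@@H]1CCOC1`, has not yet been measured. It differs from compound 2 in one place: oxolan-3-yl in place of methyl on an oxygen on an aromatic ring. Compound 1 already carries this oxolanyloxy group, and its number sits beside that of compound 2, which suggests that this exchange on the oxygen does not move the number far. Among the measured compounds shown here, no step between measured compounds that isolates this exchange is known, so the expectation rests on that comparison alone. In this assay compound 3 is estimated at 7000 nM, with a range from 2500 nM to 20000 nM. The expected step is a 1.0-fold lower number from compound 2 to compound 3 (0.01 log units; within the scatter), that is, no change beyond the scatter.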

Compound 3, half-maximal inhibitory concentration: 5460 nM
Compound 3: middle estimate off by 1.3-fold (0.11 log units), on the high side; low and high end bracket the measured number.
By their numbers in this assay, from the lowest: compounds 3, 2 and 1 (each within the scatter of the next).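

With the rest of the molecule unchanged, the exchange of methoxy for (oxolan-3-yl)oxy can now be read on its own in this assay. It gives a 1.3-fold lower number from compound 2 to compound 3 (0.12 log units; within the scatter) and so shows that, on this oxygen on an aromatic ring, a five-membered ring with a defined stereocentre can take the place of methyl without a change beyond the scatter. With the oxolanyloxy group held constant, 4-(hydroxymethyl)piperidin-1-yl in place of hydrogen on the saturated chain carbon gives a 1.7-fold lower number from compound 1 to compound 3 (0.23 log units; within the scatter) and also stays within the scatter.

On these data alone, whether a different group on this oxygen, such as a 2-(dimethylamino)ethyl chain, would move the number beyond the scatter remains open. Nothing available explains why these two exchanges leave the number so little changed.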